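Amide substitution in a bromopyrimidine diamine series

This account rests on a few compounds, and the source may have more. Where it says the series, first, only, none or still open, it means among the compounds named here.

Measured compounds:
compound 1 `CC(C)n1cc(Nc2ncc(C3CC3)c(NCCCNC(=O)C3CCC3)n2)cn1` — 4 nM
compound 2 `CC(=O)N1CCC(C(=O)NCCCNc2nc(Nc3cccc(F)c3)ncc2Br)CC1` — 430 nM

In an assay on isolated protein for inhibition of serine/threonine-protein kinase TBK1 (Homo sapiens) (a lower number here means a stronger inhibitor, a higher number a weaker inhibitor), compound 1 gives 4 nM, while compound 2 gives 430 nM, the higher of the two numbers and a gap well beyond the scatter of repeat measurements. Compound 2 therefore stands as the weaker of the pair in this assay. For the measured compounds named here, the two compounds differ in several places at once, so no single step between them is available.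

Compound 3 `O=C(NCCCNc1nc(Nc2cccc(F)c2)ncc1Br)c1ccc(C(F)(F)F)cc1` is derived from compound 2 by one change: 4-(trifluoromethyl)phenyl in place of 1-acetylpiperidin-4-yl on a carbonyl carbon. The rest of the molecule, including the bromopyrimidine diamine core and the three-carbon linker to the amide, is kept. Going by the values given here, no measured pair shows this kind of exchange, so the expectation rests on the value of compound 2 alone and carries wide uncertainty.

The estimate is that compound 3 stays close to compound 2 in this assay, with a step of a 1.2-fold higher number from compound 2 to compound 3 (0.07 log units; within the scatter) that is expected to lie within or only slightly beyond the scatter. For compound 3 the expected value is 500 nM, with a range from 150 nM to 1600 nM.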

Compound 3, half-maximal inhibitory concentration: 450 nM
Compound 3: middle estimate off by 1.1-fold (0.05 log units), on the high side, and the stated range covers the measured number.
By their numbers in this assay, from the lowest: compound 1; then compounds 2 and 3 (each within the scatter of the next).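

In this assay, for the compounds shown here, the exchange of 1-acetylpiperidin-4-yl for 4-(trifluoromethyl)phenyl on a carbonyl carbon gives a 1.0-fold higher number from compound 2 to compound 3 (0.02 log units; within the scatter) and provides the first one-place reading, with the two compounds not separated. The exchange removes a six-membered non-aromatic ring with a hetero atom, a double bond outside aromatic rings and a hydrogen-bond acceptor, and it brings in a six-membered aromatic ring of carbon only with no hydrogen-bond acceptor, yet these differences produce no readable step in this read-out; a hydrogen-bond acceptor in this group is therefore not needed for compound 3 to read level with compound 2 here. No independent measurement is available to explain why the two groups read alike.

Still open, from the compounds shown here alone, is whether a group of another kind on the same carbonyl carbon, such as a small open-chain amine, a carboxylic acid or a longer alkyl chain, would also read level with these two. Also open, going by these compounds, is whether this exchange would read alike on the core of compound 1, since compound 1 differs from compound 2 in several places at once.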